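A few compounds are considered here, and "the series" means these few. Any claim that something is new, unique, unknown or untested is made for them only; others in the source may bear on it.

Among the three compounds measured so far, compound 3 `CNC(=O)[C@H]1O[C@@H](n2cnc3c(NC4CC4)nc(Cl)nc32)[C@H](O)[C@@H]1O` sits with the second highest of the numbers: in an assay on CHO cells for displacement of a labelled ligand from adenosine receptor A3 (Homo sapiens) (on this read-out lower numbers stand for stronger inhibition and higher numbers for weaker inhibition), compound 3 gives 2.24 nM. Among the compounds with values here, compound 1 `CNC(=O)[C@H]1O[C@@H](n2cnc3c(N)nc(Cl)nc32)[C@H](O)[C@@H]1O` gives 0.398 nM in this assay, and the one-place step a 5.6-fold higher number from compound 1 to compound 3 (0.75 log units; beyond the scatter) is the only single change that has been measured. Compound 2 `CNc1nc(Cl)nc2c1ncn2[C@@H]1O[C@H](C(=O)NC2CC2)[C@@H](O)[C@H]1O` gives 2.82 nM in this assay, a number that lies within the scatter of the value of compound 3, so no order between those two can be read.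

Compound 4 `O=C(NC1CC1)[C@H]1O[C@@H](n2cnc3c(NC4CC4)nc(Cl)nc32)[C@H](O)[C@@H]1O` differs from compound 3 by cyclopropyl in place of methyl on an amide-type nitrogen. Within the data shown here, no measured step touches that amide-type nitrogen directly; the step of a 5.6-fold higher number from compound 1 to compound 3 (0.75 log units; beyond the scatter) concerns the nitrogen on the aromatic ring instead. Compound 2 does carry a cyclopropyl on the amide-type nitrogen, but it differs from compound 3 in two places, so its value only hints that such a group need not cost much. Compound 3 is therefore expected to change by a 2.0-fold higher number from compound 3 to compound 4 (0.30 log units; within the scatter), a weakening at most modest, or none beyond the scatter. The estimate for compound 4 in this assay is 4.5 nM, with a range from 1.5 nM to 14 nM.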

Compound 4, inhibition constant: 5.62 nM
Estimate against measurement, compound 4: 1.2-fold (0.10 log units) below; measured number inside the range.
By their numbers in this assay, from the lowest: compound 1; then compounds 3, 2 and 4 (each within the scatter of the next, the first and the last beyond it).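

In this assay, the amide-type nitrogen now has a step of its own: a 2.5-fold higher number from compound 3 to compound 4 (0.40 log units; beyond the scatter) shows that cyclopropyl in place of methyl at this position gives a modest weakening. With cyclopropyl already on the amide-type nitrogen, the same replacement on the nitrogen on the aromatic ring gives a 2.0-fold higher number from compound 2 to compound 4 (0.30 log units; within the scatter) and so allows no order between those two compounds. Nothing available explains the step at the amide-type nitrogen.

Still open, from the compounds shown here alone, is how an ethyl group or a longer chain on the amide-type nitrogen would compare with methyl and cyclopropyl. Going by these compounds, it also remains open whether the step at this nitrogen would keep its size with a free amino group, as in compound 1, on the aromatic ring.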